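Swapping cyclohexyl for hydroxy: a step still unmeasured

The source may report more compounds than this note shows. Statements on the series, on what has been measured and on what is new or still open speak of the compounds shown alone.

- compound 1 `O=C(/C=C/c1ccc(F)cc1)c1ccc(F)cc1` gives 22000 nM
- compound 2 `COc1cc(/C=C/C(=O)c2ccc(C3CCCCC3)cc2)cc(OC)c1` gives 39000 nM

In a functional assay (Homo sapiens) for inhibition (on this read-out higher numbers stand for weaker inhibition and lower numbers for stronger inhibition), compound 2 gives 39000 nM as its reading, and compound 1 gives 22000 nM as its reading. These two values lie within the usual scatter of each other, so the numbers do not separate compound 2 from compound 1.

Compound 3 `COc1cc(/C=C/C(=O)c2ccc(O)cc2)cc(OC)c1` differs from compound 2 in one place: hydroxy in place of cyclohexyl on an aromatic carbon, para to a large group. Counted out, the change reads hydroxy in place of cyclohexyl on an aromatic carbon and nothing else in the structure differs. Going by the values given here, no measured pair shows a change in a single place, so no direct precedent exists. Among the compounds with values here, the only guide is that compound 1, which has no cyclohexyl group, gives 22000 nM and so stays within the scatter of compound 2. No step beyond the scatter is therefore expected in this assay, with a slightly lower number if any shift appears. The estimated step is a 1.6-fold lower number from compound 2 to compound 3 (0.19 log units; within the scatter) and remains an expectation. For compound 3 the estimated value is 25000 nM with an expected range from 8000 nM to 80000 nM for repeated measurements.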

Compound 3, half-maximal inhibitory concentration: 14000 nM
Compound 3: middle estimate off by 1.8-fold (0.25 log units), on the high side, within the range that was stated.
By their numbers in this assay, from the lowest: compounds 3, 1 and 2 (each within the scatter of the next, the first and the last beyond it).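

In this assay, going by these compounds alone, putting hydroxy in place of cyclohexyl on this aromatic carbon, para to a large group, gives a 2.8-fold lower number from compound 2 to compound 3 (0.44 log units; beyond the scatter) and so provides the first comparison in which only one place differs. The step lies beyond the usual scatter, though it is modest, and it shows that the reading responds to the group at this position. It also shows that cyclohexyl is not needed here for inhibition, since the much smaller hydroxy gives stronger inhibition on the same core, yet nothing measured here says what lies behind the step.

On these data alone, with only cyclohexyl and hydroxy compared at this position, it remains open whether the reading follows the size of the group, or whether an amine, a carboxylic acid or a longer chain would give a reading closer to that of compound 2 or compound 3. As far as these compounds go, compound 1 differs from both in more than one place, so it also remains open whether the same swap would give a similar step on another core.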